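The source may report more compounds than this note shows. Statements on the series, on what has been measured and on what is new or still open speak of the compounds shown alone.

In a functional assay on HCT-116 cells (Homo sapiens), read by MTT assay, with a stated time of 72 h (a higher number here means a weaker inhibitor, a lower number a stronger inhibitor), compound 2 `Cc1nc(N)c2c(-c3cc4ccccc4o3)cn([C@@H]3O[C@H](CO)[C@@H](O)[C@H]3O)c2n1` gives only a limit, > 20000 nM. Compound 1 `Nc1nc(N)c2c(-c3cc4ccccc4o3)cn([C@@H]3O[C@H](CO)[C@@H](O)[C@H]3O)c2n1` likewise gives a limit in this assay, > 20000 nM. Compound 3 `Nc1nc2c(c(-c3ccsc3)cn2[C@@H]2O[C@H](CO)[C@@H](O)[C@H]2O)c(=O)[nH]1` also gives a limit in this assay, > 20000 nM. Within the data shown here, the step that the two limits leave unreadable from compound 1 to compound 2 is therefore not readable, and the limit of > 20000 nM in this assay, at which 3 of the 3 values shown sit, is the whole of the evidence on the series so far. Compound 4 `Cc1nc(N)c2c(I)cn([C@@H]3O[C@H](CO)[C@@H](O)[C@H]3O)c2n1` differs from compound 2 by iodo in place of 1-benzofuran-2-yl on an aromatic carbon. Among the measured compounds shown here, no measured step covers this change, and since every measured compound sits at the limit of > 20000 nM in this assay, at which 3 of the 3 values shown sit, no step beyond the scatter can be read from the numbers. Compound 4 is expected to give again only a limit in this assay, with an estimated step that the limit leaves unreadable from compound 2 to compound 4 that remains unresolved. The estimate for compound 4 is 30000 nM, within 10000 nM to 100000 nM.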

Compound 4, half-maximal inhibitory concentration: > 20000 nM
Compound 4: no number, only a limit; the forecaster's own chance of this, stated with the estimate: 85%; the middle value lies beyond the limit too.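

Among these compounds, compound 2 and compound 4 both give only a limit, so no step between them can be read. The compounds shown leave open whether any change on the shared core yields a readable number in this assay: the limit of > 20000 nM in this assay, at which 4 of the 4 values shown sit.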